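The compounds below may be only part of what the source reports. "The series", "measured", "known", "first", "only" and "open" are said of these compounds alone.

Compound 1 `Cc1cccc([S+]([O-])c2cccc(N)c2C#N)c1`: > 200000 nM
Compound 2 `N#Cc1cccc([S+]([O-])c2cccc(N)c2C#N)c1`: > 200000 nM

In a functional assay on MT4 cells (Homo sapiens) for cytotoxicity (a higher number here means a weaker inhibitor, a lower number a stronger inhibitor), compound 1 gives > 200000 nM. From the compounds shown here alone, that value is a limit and not a number, so the exact standing of compound 1 is unknown. Compound 2 gives > 200000 nM, which is also a limit. The picture so far is therefore (the limit of > 200000 nM in this assay, at which 2 of the 2 values shown sit).

Compound 3 `Cc1cc(C)cc([S+]([O-])c2cccc(N)c2C#N)c1` keeps the core of compound 1 and adds one group: methyl in place of hydrogen on an aromatic carbon. This places methyl in place of hydrogen on an aromatic carbon, meta to a large group and meta to a methyl group.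

Among the measured compounds shown here, only one measured step bears on this change, and it is a step that the two limits leave unreadable from compound 1 to compound 2. That step swaps cyano for methyl on an aromatic carbon, and it offers no size to carry over. With no readable step to build on, no change beyond the usual scatter is expected in this assay. The expected step is a number no higher from compound 1 to compound 3 (the limit leaves the size open). A further limit is the most likely outcome. For compound 3 the estimated value is 200000 nM, with an expected range from 100000 nM to 400000 nM.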

Compound 3, half-maximal inhibitory concentration: 200000 nM
Compound 3: the middle estimate sits on the measured number at the digits printed, and the stated range covers the measured number.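

In this assay compound 3 gives 200000 nM, the only value among the three shown that is a number and not a limit. Adding methyl in place of hydrogen on this aromatic carbon, meta to a large group and meta to a methyl group, yields a number no higher from compound 1 to compound 3 (the limit leaves the size open), so this step cannot be read as a size and gives only a direction. The number for compound 3 also stands at the same figure as the limit shared by the other two compounds, which shows that this second methyl group brings no readable move away from that figure: the limit of > 200000 nM in this assay, at which 2 of the 3 values shown sit.

The compounds shown leave open whether a different group at this position, such as an amine, a carboxylic acid or a longer chain, would bring the value clearly under that figure. They also leave open how far under the limit any change to the shared core could reach in this assay, since no value shown lies well away from it.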